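The source may hold more compounds than are shown below. What is called first, only, known or untested is meant among the compounds shown, and "the series" means these compounds.

Three measured compounds share one core and differ only in the group carried on an aromatic carbon of the anilide ring. Compound 1 is `O=C(CCCCCCn1cc(-c2cccnc2)nn1)Nc1ccccc1-c1ccccc1`, compound 2 is `O=C(CCCCCCn1cc(-c2cccnc2)nn1)Nc1ccccc1Cc1ccccc1` and compound 3 is `COc1ccccc1NC(=O)CCCCCCn1cc(-c2cccnc2)nn1`. In a functional assay on SH-SY5Y cells (Homo sapiens) for cytotoxicity, tested at 300 nM (a higher number here means a weaker effect of the compound at the concentration tested, a lower number a stronger effect), compound 1 gives 88.2%, compound 2 gives 86.1% and compound 3 gives 87.9%. Compound 3 has the second highest of the three numbers; its nearest neighbour is compound 1, with a number 0.3 percentage points lower from compound 1 to compound 3 (within the scatter), and its furthest is compound 2, with a number 1.8 percentage points higher from compound 2 to compound 3 (within the scatter), so all three values sit within the scatter of one another.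

The next compound, compound 4, is `O=C(CCCCCCn1cc(-c2cccnc2)nn1)Nc1ccccc1Cl`. Relative to compound 3 the change is chloro in place of methoxy on an aromatic carbon. For the measured compounds named here, the steps that bear on it are the swaps at this same aromatic carbon: a number 2.1 percentage points lower from compound 1 to compound 2 (within the scatter), a number 0.3 percentage points lower from compound 1 to compound 3 (within the scatter) and a number 1.8 percentage points higher from compound 2 to compound 3 (within the scatter). None of them moved the read-out beyond the scatter, even though phenyl, benzyl and methoxy are quite different groups. On this basis the step of a number 0.4 percentage points lower from compound 3 to compound 4 (within the scatter) is expected to stay within the scatter as well, in no clear direction. Compound 4 is therefore estimated to give 87.5% in this assay, with a range from 79% to 95%.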

Compound 4, a percentage reported as activity, at one concentration (the size of the read-out at that concentration, not a potency): 79.5%
Compound 4: middle estimate off by 8 percentage points, on the high side, within the range that was stated.
By their numbers in this assay, from the lowest: compounds 4, 2, 3 and 1 (each within the scatter of the next).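

At this aromatic carbon of the anilide ring, chloro gives steps of a larger size than any seen among phenyl, benzyl and methoxy: in this assay the three steps read (a number 8.4 percentage points lower from compound 3 to compound 4 (within the scatter)) and (a number 6.6 percentage points lower from compound 2 to compound 4 (within the scatter)) and (a number 8.7 percentage points lower from compound 1 to compound 4 (within the scatter)). All three are still within the scatter, so compound 4 cannot be set apart from compound 1, compound 2 or compound 3, and no swap at this position has yet moved the read-out beyond the scatter, even with a group of a single heavy atom in place of methoxy. Nothing measured here offers an explanation for the larger size of these steps.

Going by these compounds, it remains open whether these larger steps mark a real difference for chloro or only the spread of single readings at one concentration, which a second halogen such as fluoro or bromo at the same carbon would help to judge. Also open, on these data alone, is whether an amine or a carboxylic acid on this carbon, or a longer chain in the shared core, would produce a step beyond the scatter in this assay at all.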